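The compounds below may be only part of what the source reports. "The series", "measured", "known", "first", "only" and "open" are said of these compounds alone.

Compound 1, `O=C(NCCCCn1cccn1)c1cccc(C2SCC(=O)N2c2ccccn2)c1`, gives 82.1 mL.min-1.g-1 in an ADME assay on microsomes from liver (Homo sapiens) for metabolic stability, read by LC-MS, using NADPH, with a stated time of 10 min, tested at 0.1 uM; a lower number here means slower removal, a higher number faster removal of the compound.
Compound 2, `O=C(NCCCCc1ccccc1)c1cccc(C2SCC(=O)N2c2cccc(F)c2)c1`, gives 1840 mL.min-1.g-1 in this assay.
Compound 3, `C#Cc1cc(C(=O)NCCCCc2ccccc2)cc(C2SCC(=O)N2c2ccccc2OC)c1`, gives 1730 mL.min-1.g-1 in this assay.

Compound 2 has the highest number of the three. Its nearest neighbour is compound 3, whose value lies within the scatter of that of compound 2, while compound 1 stands far lower, well beyond the scatter. Compound 4, `CC(F)(F)c1cccc(N2C(=O)CSC2c2cccc(C(=O)NCCCCc3ccccc3)c2)c1`, differs from compound 2 in one place: 1,1-difluoroethyl in place of fluoro on an aromatic carbon. Among the measured compounds shown here, no pair of measured compounds differs by this change alone, so no measured step is available for it. A small step is expected here, with no direction that would stand beyond the scatter, because compound 2 already gives 1840 mL.min-1.g-1 and nothing measured points elsewhere. Compound 4 is therefore estimated at 1500 mL.min-1.g-1 in this assay, within 700 mL.min-1.g-1 to 3200 mL.min-1.g-1, which is a step of a 1.2-fold lower number from compound 2 to compound 4 (0.09 log units; within the scatter).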

Compound 4, intrinsic clearance in microsomes: 1750 mL.min-1.g-1
The estimate for compound 4 lay 1.2-fold (0.07 log units) below the measured number; the range from low to high includes it.
By their numbers in this assay, from the lowest: compound 1; then compounds 3, 4 and 2 (each within the scatter of the next).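

Putting 1,1-difluoroethyl in place of fluoro on this aromatic carbon, meta to a large group, gives a 1.1-fold lower number from compound 2 to compound 4 (0.02 log units; within the scatter) in this assay. At this position, then, a group of 4 heavy atoms can take the place of one of 1 heavy atom with the number staying within the scatter. Nothing shown here gives a reason for this result.

Going by these compounds, whether an amine or a carboxylic acid on this aromatic carbon would give a step beyond the scatter stays open. So does whether the same step would hold with a different amide chain, such as that of compound 1.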